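The compounds below may be only part of what the source reports. "The series", "measured", "known", "first", "only" and "open" are said of these compounds alone.

Compound 1, `COc1cccc(Cc2cc(-c3ccccc3)nn(CC(=O)Nc3ccc(Br)cc3)c2=O)c1`, in an assay on HL-60 cells for agonist activity at N-formyl peptide receptor 3 (Homo sapiens), read by calcium flux (a lower number here means that less compound is needed, a higher number that more compound is needed for the effect), gives > 50000 nM, which is a limit of the assay and not a number.
Compound 2, `COc1ccc(-c2cc(Cc3cccc(OC)c3)c(=O)n(CC(=O)Nc3ccc(F)cc3)n2)cc1`, gives > 50000 nM in this assay, again a limit rather than a number.
Compound 3, `Cc1cc(Cc2cccc(F)c2)c(=O)n(CC(=O)Nc2ccc(Br)cc2)n1`, gives > 50000 nM in this assay, also a limit rather than a number.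

All three measured compounds therefore sit at the limit of > 50000 nM in this assay, at which 3 of the 3 values shown sit. Nothing in these numbers separates compound 3 from the other two, and no ranking among them is possible. For the measured compounds named here, no measured step between any pair of them exists, so no size of change has been seen in this assay.

Compound 4, `Cc1cc(Cc2ccc(C(F)(F)F)cc2)c(=O)n(CC(=O)Nc2ccc(Br)cc2)n1`, differs from compound 3 in one place: 4-(trifluoromethyl)phenyl in place of 3-fluorophenyl on a saturated chain carbon bound to an aromatic carbon. Going by the values given here, no measured pair shows what such a change does here, so the expectation rests only on where compound 3 stands, at a limit of the assay. The expected step of a number no higher from compound 3 to compound 4 (the limit leaves the size open) is no change beyond the scatter, and a limit is again the most likely report. Compound 4 is estimated at 50000 nM, within a range from 10000 nM to 200000 nM.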

Compound 4, half-maximal effective concentration: > 50000 nM
Compound 4 ended at the assay's limit; the forecaster's own chance of this, stated with the estimate: 85%; the middle value lies on the limit itself.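

Compound 3 and compound 4 both stand at a limit of this assay and not at a number, so no step between them can be read: the limit of > 50000 nM in this assay, at which 4 of the 4 values shown sit.

Left open is how much of any of these compounds the effect would take, and which change to the shared core, if any, would bring a readable number.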